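Aryl swap on the piperazine nitrogen: compound 3 to compound 4

The source may report more compounds than this note shows. Statements on the series, on what has been measured and on what is new or still open speak of the compounds shown alone.

Three compounds of the series carry a measured number in a functional assay on the whole organism (Abdomen, strain Swiss) for inhibition, with Mus musculus as the target, with stated times of 30 min, 10 min and 5 min, at a dose of 40 mg/kg by the oral route; on this read-out lower numbers stand for a weaker effect and higher numbers for a stronger effect at the one dose given. Compound 1 `CCCCC(=O)c1c(C)nn(CCCN2CCN(c3ccc(C)cc3)CC2)c(=O)c1N` gives 15% in this assay. Compound 2 `C/C=C/c1c(C)nn(CCCN2CCN(c3ccc(C)cc3)CC2)c(=O)c1N` gives 63% in this assay. Compound 3 `CC(=O)c1cccn1CCCN1CCN(c2ccc(F)cc2)CC1` gives 38% in this assay, which places it second highest of the three: above compound 1 beyond the scatter and below compound 2 beyond the scatter.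

Going by the values given here, the only single-point step measured so far is a number 48 percentage points higher from compound 1 to compound 2 (beyond the scatter), a change on an aromatic carbon of the core shared by compound 1 and compound 2. The step now followed is of a different kind: compound 4 `COc1cccc(N2CCN(CCCn3cccc3C(C)=O)CC2)c1` differs from compound 3 by 3-methoxyphenyl in place of 4-fluorophenyl on an amine nitrogen in a ring. Among the compounds with values here, no measured pair changes the aryl group on that ring nitrogen, and the core of compound 3 is not the core on which the large step between compound 1 and compound 2 was seen. The measured step therefore gives no direct guide to the direction or size of this change.

On that basis no step beyond the scatter is expected from compound 3 to compound 4, and the expected step of no change at the digits printed from compound 3 to compound 4 (within the scatter) reflects this, with a wide range to cover the lack of a bearing precedent. Compound 4 is estimated at 38% in this assay, with a range from 15% to 60%.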

Compound 4, a percentage reported as inhibition, in the whole organism at one dose (the size of the read-out at that dose, not a potency): 52%
Estimate against measurement, compound 4: 14 percentage points below, within the range that was stated.
By their numbers in this assay, from the lowest: compound 1; then compound 3; then compound 4; then compound 2.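

In this assay, going by these compounds alone, the aryl group on the amine nitrogen in a ring proves to be a position where the read-out responds: 3-methoxyphenyl in place of 4-fluorophenyl gives a number 14 percentage points higher from compound 3 to compound 4 (beyond the scatter), the first measured step at this position and the first on the core of compound 3. The step changes the identity of the substituent and its place on the phenyl ring together, and the entering group also brings the hydrogen-bond acceptor counted for it, so this single pair cannot assign the gain to any one of these differences. No measurement offered here bears on the origin of the step.

The compounds shown leave open whether 4-methoxyphenyl or 3-fluorophenyl on the same ring nitrogen would separate the effect of the substituent from that of its place, and where unsubstituted phenyl would stand relative to compound 3 and compound 4. They also leave open whether the same aryl swap would move the read-out in the same direction on the core shared by compound 1 and compound 2.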